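The source may report more compounds than this note shows. Statements on the series, on what has been measured and on what is new or still open speak of the compounds shown alone.

Measured compounds:
compound 1 `CCOC(=O)c1cccc(-c2ccsc2)c1`: 67%
compound 2 `CCOc1ccc(-c2cccc([N+](=O)[O-])c2)cc1`: 35%
compound 3 `CN(C)c1ccc(-c2cccc([N+](=O)[O-])c2)cc1`: 21%

In an assay on COS-7 cells for inhibition of patatin-like phospholipase domain-containing protein 2 (Mus musculus), tested at 200 uM (a lower number here means less inhibition, a higher number more inhibition at the concentration tested (going by the name of the read-out)), compound 3 stands lowest of the three; compound 2 is nearest, the step being a number 14 percentage points lower from compound 2 to compound 3 (beyond the scatter), and compound 1 lies furthest, beyond the scatter. Compound 4 `CN(C)c1ccc(-c2cccc(NC(=O)C(C)(C)C)c2)cc1` follows from compound 3 by ((tert-butyl)carbonyl)amino in place of nitro on an aromatic carbon. Within the data shown here, no measured step bears on an exchange of the nitro; the only step available, a number 14 percentage points lower from compound 2 to compound 3 (beyond the scatter), concerns the dimethylamino in place of ethoxy and is modest. There is therefore no basis for expecting a step beyond the scatter in this assay in either direction. Compound 4 is estimated at 25% (range 5% to 50%), the expected step of a number 4 percentage points higher from compound 3 to compound 4 (within the scatter) being within the scatter.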

Compound 4, a percentage reported as inhibition, at one concentration (the size of the read-out at that concentration, not a potency): 25%
Estimate against measurement, compound 4: no gap at the digits printed; the range from low to high includes it.
By their numbers in this assay, from the lowest: compounds 3, 4 and 2 (each within the scatter of the next, the first and the last beyond it); then compound 1.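

In this assay, ((tert-butyl)carbonyl)amino in place of nitro on this aromatic carbon gives a number 4 percentage points higher from compound 3 to compound 4 (within the scatter). The nitro is therefore not needed to hold the read-out of compound 3 at this position, and a larger group carrying a hydrogen-bond donor is accommodated on the same core without a step beyond the scatter. No measurement available here accounts for this result.

Going by these compounds, whether the exchange behaves alike with ethoxy in place of dimethylamino remains open. So does the outcome with a free amine or a carboxylic acid on this aromatic carbon.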